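Methyl in place of chloro: compound 2 to compound 4

The compounds below may be only part of what the source reports. "The series", "measured", "known", "first", "only" and "open" are said of these compounds alone.

In a functional assay on Bel-7402 cells (Homo sapiens) for inhibition, read by MTT assay, with a stated time of 24 h, tested at 10 ug/mL (on this read-out higher numbers stand for more inhibition of growth at the one concentration tested and lower numbers for less inhibition of growth), compound 1 `O=C(CCCCC(S)CCS)Nc1ccccc1Cl` is recorded as "not active" (no number reported) with no number given. Compound 2 `O=C(CCCCC(S)CCS)Nc1cccc(Cl)c1` gives 3.22% and compound 3 `O=C(CCCCC(S)CCS)Nc1ccc(F)cc1` gives 6.14% so these two stand within the scatter of each other. Compound 4 `Cc1cccc(NC(=O)CCCCC(S)CCS)c1` differs from compound 2 by methyl in place of chloro on an aromatic carbon. For the measured compounds named here, no measured pair differs in one place only, so the data offer no direct guide to the size of this change. The estimated step of a number 1.8 percentage points higher from compound 2 to compound 4 (within the scatter) is expected to stay within the scatter of this assay and to have no firm direction. Compound 4 is estimated at 5% with 0% to 15% as the expected range.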

Compound 4, percent growth inhibition at one concentration: 14.1%
Beside the measured number, compound 4's estimate is 9.1 percentage points below it; measured number inside the range.
By their numbers in this assay, from the lowest: compounds 2, 3 and 4 (each within the scatter of the next, the first and the last beyond it).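

In this assay, for the compounds shown here, methyl in place of chloro on an aromatic carbon, meta to a large group, gives the first measured single-place step: a number 10.9 percentage points higher from compound 2 to compound 4 (beyond the scatter). This position therefore responds to exchanging one heavy atom for another, though only modestly and on the evidence of one pair. Nothing measured here accounts for the step. Still open, on these data alone, is whether an amine, a methoxy group or an ethyl group at this place would go beyond methyl. Also open, as far as these compounds go, is whether methyl in place of the chloro of compound 1 gives a similar step.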